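Extending the ethyl thioether to heptyl on the oxabicyclic core

The source may hold more compounds than are shown below. What is called first, only, known or untested is meant among the compounds shown, and "the series" means these compounds.

Two compounds share a bicyclic ether core carrying a heptenoic acid chain and a sulfur-linked side chain. Compound 1 `O=C(O)CCC/C=C\CC1C2CCC(O2)C1CSCCc1ccccc1` gives 5500 nM in a functional assay on a cell-free system (plasma) for inhibition of thromboxane A2 receptor (Homo sapiens); a higher number here means a weaker inhibitor, a lower number a stronger inhibitor. Compound 2 `CCSCC1C2CCC(O2)C1C/C=C\CCCC(=O)O` gives 5400 nM in this assay, and the two numbers sit together within the usual scatter, as the step of a 1.0-fold lower number from compound 1 to compound 2 (0.01 log units; within the scatter) shows: removing the phenyl from the side chain left the inhibition where it was. Compound 3 `CCCCCCCSCC1C2CCC(O2)C1C/C=C\CCCC(=O)O` differs from compound 2 by pentyl in place of hydrogen on a saturated chain carbon, two bonds along the chain from a sulfur. For the measured compounds named here, only the step from compound 1 to compound 2 bears on this change, and it was flat; a longer plain chain in place of the phenyl-bearing chain is therefore expected to move the number little, if at all, beyond the scatter. Compound 3 is estimated at 4000 nM in this assay, between 1500 nM and 12000 nM, which means an expected step of a 1.4-fold lower number from compound 2 to compound 3 (0.13 log units; within the scatter).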

Compound 3, half-maximal inhibitory concentration: 42000 nM
For compound 3 the middle estimate is 11-fold (1.02 log units) below the measured one, and the stated range ends below it.
By their numbers in this assay, from the lowest: compounds 2 and 1 (each within the scatter of the next); then compound 3.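

Pentyl at this place is not a neutral change, as the flat earlier step might have suggested: in this assay the heptyl chain gives a 7.8-fold higher number from compound 2 to compound 3 (0.89 log units; beyond the scatter) for the switch from ethylsulfanyl to heptylsulfanyl. Pentyl in place of phenyl gives a 7.6-fold higher number from compound 1 to compound 3 (0.88 log units; beyond the scatter) in the same direction, so the ethyl compound and the phenyl-bearing compound, which sit together within the scatter, both stand apart from compound 3 by much the same step. No evidence is available to account for this weaker inhibition.

The compounds shown leave open whether the number climbs steadily with chain length or only once the chain passes a certain length, which a propyl or butyl chain on the sulfur would help to settle. They also leave open whether a heptyl chain ending in an amine or a hydroxyl would behave like the plain heptyl chain.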